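Nitro in place of chloro: compound 1 to compound 4

The source may report more compounds than this note shows. Statements on the series, on what has been measured and on what is new or still open speak of the compounds shown alone.

Measured in a functional assay on the whole organism (strain albino) with Mus musculus as the target, in the maximal electroshock model, with a stated time of 0.5 h; on this read-out higher numbers stand for an effect only at larger amounts of compound and lower numbers for an effect already at smaller amounts:
compound 1 `O=C1c2ccccc2C(=O)N1c1cccc(Cl)c1`: 190 mg/kg
compound 2 `O=C1c2ccccc2C(=O)N1c1ccccc1F`: > 300 mg/kg (a limit, not a number)
compound 3 `O=C1c2ccccc2C(=O)N1c1ccccc1[N+](=O)[O-]`: 53.5 mg/kg

Compound 1 at 190 mg/kg holds the higher of the two actual numbers. Compound 3 at 53.5 mg/kg is the nearest, lower by a gap beyond the scatter. Compound 2 gives only a limit, > 300 mg/kg.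

Compound 4 `O=C1c2ccccc2C(=O)N1c1cccc([N+](=O)[O-])c1` carries nitro in place of chloro on an aromatic carbon, meta to a large group (nitro in place of chloro on an aromatic carbon). Going by the values given here, one measured step bears on this change: an at least 5.6-fold lower number from compound 2 to compound 3 (0.74 log units; beyond the scatter). That step replaces fluoro rather than chloro and starts from the limit of > 300 mg/kg in this assay, at which 1 of the 3 values shown sits, so it gives a direction but no exact size. A modest move to a lower number in this assay is therefore expected, smaller than that measured step. The expected change is a 2.1-fold lower number from compound 1 to compound 4 (0.32 log units; beyond the scatter). For compound 4 the estimated value is 90 mg/kg, with an expected range of 30 mg/kg to 280 mg/kg.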

Compound 4, dose for half-maximal effect: 174 mg/kg
Estimate against measurement, compound 4: 1.9-fold (0.29 log units) below; measured number inside the range.
By their numbers in this assay, from the lowest: compound 3; then compounds 4 and 1 (each within the scatter of the next). At a limit, above all of these: compound 2.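

In this assay, nitro in place of chloro on the aromatic carbon meta to a large group gives a 1.1-fold lower number from compound 1 to compound 4 (0.04 log units; within the scatter), so at this position the two groups cannot be told apart on this read-out. Going by these compounds alone, the only earlier step involving nitro, an at least 5.6-fold lower number from compound 2 to compound 3 (0.74 log units; beyond the scatter), replaced fluoro rather than chloro, and compound 4 shows that entry of nitro does not lower the number beyond the scatter in every case. Compound 2 stands at a limit and not at a number, so the size of that earlier step remains open-ended: the limit of > 300 mg/kg in this assay, at which 1 of the 4 values shown sits.

The compounds shown leave open whether an amine or a carboxylic acid on this same aromatic carbon would move the number beyond the scatter. They also leave open whether nitro and chloro would match on other aromatic carbons of the ring.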